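Ester-side amide variants on a beta-lactone core

The source may report more compounds than this note shows. Statements on the series, on what has been measured and on what is new or still open speak of the compounds shown alone.

Measured so far:
compound 1, `CCCCCCCCCCC[C@@H](C[C@@H]1OC(=O)[C@H]1CCCCCC)OC(=O)[C@H](C)NC=O`, an assay on membranes from brain for inhibition of Fatty-acid amide hydrolase 1 (Rattus norvegicus); a lower number here means a stronger inhibitor, a higher number a weaker inhibitor: > 50000 nM
compound 2, `CCCCCCCCCCC[C@@H](C[C@@H]1OC(=O)[C@H]1CCCCCC)OC(=O)CCNC=O`: > 50000 nM

Both values are limits of the assay, not numbers. For compound 2 the value > 50000 nM is a limit. For compound 1 the value > 50000 nM is likewise a limit, so the step that the two limits leave unreadable from compound 1 to compound 2 cannot be read, as the limit of > 50000 nM in this assay, at which 2 of the 2 values shown sit, shows.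

Compound 3, `CCCCCCCCCCC[C@@H](C[C@@H]1OC(=O)[C@H]1CCCCCC)OC(=O)[C@@H](NC(C)=O)C(C)CC`, is not yet measured. It differs from compound 2 by 1-acetamido-2-methylbutyl in place of 2-(formylamino)ethyl on a carbonyl carbon. Going by the values given here, no measured step bears on this change: the only step, from the formylamino-alanine ester to the formylamino-propanoate ester, lies between two limits. Compound 2 itself stands at the limit, so there is no number from which a direction could be read.

Compound 3 is therefore expected to give 60000 nM (range 10000 nM to 200000 nM), most likely again reported as a limit. The step that the limit leaves unreadable from compound 2 to compound 3 is thus estimated to be none beyond the scatter.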

Compound 3, half-maximal inhibitory concentration: 6600 nM
The estimate for compound 3 lay 9.1-fold (0.96 log units) above the measured number; measured number below the stated range.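

In this assay, the place on a carbonyl carbon proves able to give a readable inhibition value: 1-acetamido-2-methylbutyl in place of 2-(formylamino)ethyl brings an at least 7.5-fold lower number from compound 2 to compound 3 (0.87 log units; beyond the scatter). Against the alanine-derived ester the same place shows an at least 7.5-fold lower number from compound 1 to compound 3 (0.87 log units; beyond the scatter), so the ester side of the shared core does affect the read-out, which the earlier pair could not show. The step from compound 1 to compound 2 remains unreadable: the limit of > 50000 nM in this assay, at which 2 of the 3 values shown sit.

The change swaps formyl for acetyl on the nitrogen and also adds the branched carbon chain, so the compounds shown do not tell which of the two carries the step. Also open, on these data alone, is how a free amine or a longer unbranched chain would read at this place.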